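The compounds below may be only part of what the source reports. "The series", "measured", "known", "first", "only" and "open" are said of these compounds alone.

In a physicochemical assay for lipophilicity (a higher number here means a more lipophilic compound, a lower number a more polar compound), compound 1 (`CC[C@@H]1C(=O)N(C)c2cnc(-n3ccnc3-c3ccccc3)nc2N1[C@@H]1CCOC1`) gives 1.8, while compound 2 (`CC[C@@H]1C(=O)N(C)c2cnc(-n3ccnc3-c3ccc(F)cc3)nc2N1CCC(F)(F)F`) gives 3.1, the higher of the two numbers and a gap beyond the usual scatter. The not yet measured compound 3 (`CC[C@@H]1C(=O)N(C)c2cnc(-n3ccnc3-c3ccccc3)nc2N1CCC(F)(F)F`) differs from compound 2 in one place: hydrogen in place of fluoro on an aromatic carbon. For the measured compounds named here, no measured pair shows this change on its own, so only a modest expectation is possible: a small downward move in this assay that may stay within the scatter, an estimated a number 0.20 log units lower from compound 2 to compound 3 (within the scatter). For compound 3 the expected value is 2.9, with a range of 2.6 to 3.2.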

Compound 3, partition coefficient: 3.1
Compound 3: the middle estimate sits 0.20 log units below what was measured; the measured number falls inside the stated range.
By their numbers in this assay, from the lowest: compound 1; then compounds 2 and 3 (each within the scatter of the next).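

Changing 4-fluorophenyl to phenyl gives no change at the digits printed from compound 2 to compound 3 (within the scatter) in this assay, so in this pair the fluoro on the aromatic carbon makes no readable difference. Compound 3 also isolates the change on the nitrogen, where 3,3,3-trifluoropropyl in place of oxolan-3-yl gives a number 1.30 log units higher from compound 1 to compound 3 (beyond the scatter) as a large step from one change alone. The data shown offer no explanation for either step. As far as these compounds go, whether chloro or methoxy on that aromatic carbon would behave like fluoro remains open. So does the effect of an amine or a longer chain on the nitrogen.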